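The source may hold more compounds than are shown below. What is called first, only, known or untested is meant among the compounds shown, and "the series" means these compounds.

Compound 1 `Cc1ccc(S(=O)(=O)N2N=C(c3ccc(N4CCN(C)CC4)cc3)CC2c2ccc(N(C)C)cc2)cc1` gives the higher of the two measured numbers in a functional assay on NCI-H1975 cells (Homo sapiens) for inhibition, read by sulforhodamine B assay, tested at 10 uM (a higher number here means more inhibition at the concentration tested (going by the name of the read-out), a lower number less inhibition), where compound 1 gives 38.1%. Compound 2 `CN1CCN(c2ccc(C3=NN(S(=O)(=O)c4ccc(OC(F)(F)F)cc4)C(c4ccc(N(C)C)cc4)C3)cc2)CC1`, made by trifluoromethoxy in place of methyl on an aromatic carbon, gives 26.5%, a change of a number 11.6 percentage points lower from compound 1 to compound 2 (beyond the scatter). Compound 3 `Cc1ccc(S(=O)(=O)N2N=C(c3ccc(-n4ccnc4)cc3)CC2c2ccc(N(C)C)cc2)cc1` carries a different change: 1H-imidazol-1-yl in place of 4-methylpiperazin-1-yl on an aromatic carbon. Among the measured compounds shown here, the one measured step touches another part of the shared core, so nothing measured bears directly on this change, and wide uncertainty remains. A step of a number 8.1 percentage points lower from compound 1 to compound 3 (within the scatter) is therefore expected, with compound 3 estimated at 30%, between 10% and 50%.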

Compound 3, a percentage reported as inhibition, at one concentration (the size of the read-out at that concentration, not a potency): 50.5%
Estimate against measurement, compound 3: 20.5 percentage points below, outside the stated range (above it).
By their numbers in this assay, from the lowest: compound 2; then compound 1; then compound 3.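

Putting 1H-imidazol-1-yl in place of 4-methylpiperazin-1-yl gives a number 12.4 percentage points higher from compound 1 to compound 3 (beyond the scatter) in this assay. This position, on an aromatic carbon para to a large group, therefore affects the read-out, and a five-membered aromatic ring can stand there without loss of inhibition at the concentration tested. No evidence is available to explain this rise.

Going by these compounds, whether this gain carries over to the trifluoromethoxy series of compound 2 remains open. A morpholin-4-yl or 1H-pyrazol-1-yl group on the same carbon would show whether the gain is specific to 1H-imidazol-1-yl.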